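The source may hold more compounds than are shown below. What is called first, only, known or untested is meant among the compounds shown, and "the series" means these compounds.

In a functional assay on MCF7 cells (Homo sapiens) for inhibition, read by MTT assay, with a stated time of 48 h (a lower number here means a stronger inhibitor, a higher number a weaker inhibitor), so far:

compound 1 `CC(=O)c1ccc(Nc2c(C(C)=O)sc(NC(=O)CC#N)c2C#N)cc1` gives 41400 nM
compound 2 `CC(=O)Nc1sc(C(C)=O)c(Nc2ccc(C(C)=O)cc2)c1C#N` gives 64600 nM
compound 3 `CC(=O)c1ccc(Nc2c(C(=O)/C=C/c3ccccc3)sc(N)c2C#N)cc1` gives 67500 nM

Among the measured compounds shown here, compound 3 at 67500 nM lies within the scatter of both compound 1 and compound 2, so these three values set no order among the compounds. The next compound to be measured is compound 4 `CC(=O)c1ccc(Nc2c(C(C)=O)sc(N)c2C#N)cc1` and it differs from compound 3 by methyl in place of 2-phenylethenyl on a carbonyl carbon in a single change.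

For the measured compounds named here, no measured step covers this change directly. Going by the values given here, the only measured step lies at another place: hydrogen in place of cyano on a saturated chain carbon bound to a carbonyl carbon gives a 1.6-fold higher number from compound 1 to compound 2 (0.19 log units; within the scatter) and stays within the scatter. Compound 1 and compound 2 already carry methyl on the carbonyl carbon in question, but they also differ from compound 4 at another place, so they give only a rough guide. Even so, compound 1 at 41400 nM and compound 2 at 64600 nM give no sign of a separation from compound 3 in this assay.

The expected change is a 1.2-fold lower number from compound 3 to compound 4 (0.09 log units; within the scatter) and is thus no step beyond the scatter. Compound 4 is estimated at 55000 nM with an expected range from 22000 nM to 120000 nM in this assay.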

Compound 4, half-maximal inhibitory concentration: 91500 nM
For compound 4 the middle estimate is 1.7-fold (0.22 log units) below the measured one; measured number inside the range.
By their numbers in this assay, from the lowest: compounds 1, 2, 3 and 4 (each within the scatter of the next, the first and the last beyond it).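

In this assay, methyl in place of 2-phenylethenyl on the carbonyl carbon gives a 1.4-fold higher number from compound 3 to compound 4 (0.13 log units; within the scatter) and so removes a group of 8 heavy atoms, with its six-membered aromatic ring and its double bond, without a change that can be told from the scatter. At the nitrogen on the aromatic ring the picture differs slightly: hydrogen in place of acetyl gives a 1.4-fold higher number from compound 2 to compound 4 (0.15 log units; within the scatter) while hydrogen in place of (cyanomethyl)carbonyl gives a 2.2-fold higher number from compound 1 to compound 4 (0.34 log units; beyond the scatter) and is the only step among these compounds that clears the scatter, so the free amino nitrogen separates only from the cyano-bearing acyl group, and only modestly. No measurement available here accounts for either step.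

From the compounds shown here alone, whether the carbonyl carbon would respond to anything other than these two groups stays open, for instance a longer saturated chain or a phenyl ring placed directly on it. Equally open, going by these compounds, is whether the small separation at the nitrogen would hold or grow with other acyl groups, such as one ending in a carboxylic acid or a tertiary amine.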